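A Shorter Chain with a Double Bond on a Shared Core

This account rests on a few compounds, and the source may have more. Where it says the series, first, only, none or still open, it means among the compounds named here.

Measured compounds:
Compound 1, `CCCOc1ccc(C(CC(=O)O)c2ccccc2)cc1`, 4.8 uM
Compound 2, `CCCCCOc1ccc(C(CC(=O)O)c2ccccc2)cc1`, 2.97 uM
Compound 3, `CCCCCCOc1ccc(C(CC(=O)O)c2ccccc2)cc1`, 2.88 uM

All three were tested in a functional assay on HEK293 cells for agonist activity at Free fatty acid receptor 1 (Homo sapiens), read by calcium flux; a higher number here means that more compound is needed for the effect, a lower number that less compound is needed. Compound 3 gives the lowest number of the three, but its nearest neighbour compound 2 sits at a 1.0-fold lower number from compound 2 to compound 3 (0.01 log units; within the scatter), and even compound 1 is only a 1.7-fold lower number from compound 1 to compound 3 (0.22 log units; within the scatter) away, so the three values cannot be told apart with confidence.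

Compound 4, `C/C=C/COc1ccc(C(CC(=O)O)c2ccccc2)cc1`, has not yet been measured. It differs from compound 3 in one place: prop-1-en-1-yl in place of pentyl on a saturated chain carbon bound to an oxygen on an aromatic ring. Cut one bond further out, the change reads hexyloxy to (but-2-en-1-yl)oxy, so the chain on the ring oxygen becomes shorter and gains a double bond.

The measured steps that bear on this all concern the length of this chain. Lengthening it from compound 1 gave a 1.6-fold lower number from compound 1 to compound 2 (0.21 log units; within the scatter) and a 1.7-fold lower number from compound 1 to compound 3 (0.22 log units; within the scatter), and a further step gave a 1.0-fold lower number from compound 2 to compound 3 (0.01 log units; within the scatter). Shortening the chain in compound 4 is therefore expected to move the number, if at all, back toward that of compound 1, with the double bond an untested element. The expected step is a 1.4-fold higher number from compound 3 to compound 4 (0.14 log units; within the scatter), and compound 4 is estimated at 4 uM, within 2 uM to 8 uM.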

Compound 4, concentration for half-maximal effect: 2.71 uM
The estimate for compound 4 lay 1.5-fold (0.17 log units) above the measured number; the measured number falls inside the stated range.
By their numbers in this assay, from the lowest: compounds 4, 3, 2 and 1 (each within the scatter of the next).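

Replacing hexyloxy with (but-2-en-1-yl)oxy on the ring oxygen leaves the number in this assay unresolved from that of compound 3, with a 1.1-fold lower number from compound 3 to compound 4 (0.03 log units; within the scatter) as the step. The comparison with compound 2 reads the same way, at a 1.1-fold lower number from compound 2 to compound 4 (0.04 log units; within the scatter), and even the step from the saturated chain of compound 1 stays small, at a 1.8-fold lower number from compound 1 to compound 4 (0.25 log units; within the scatter). The earlier compounds shown here varied only the length of a saturated chain, so this result adds that a shorter chain carrying a double bond can sit at this place without a change that can be told from the scatter, and none of the four compounds separates from the others.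

Nothing measured in this set gives a reason for these closely grouped numbers, so the result remains an observation without an explanation. Also open, from the compounds shown here alone, is whether a saturated butyl chain would match compound 4, which would separate the double bond from the chain length, and whether a chain carrying an amine or a phenyl ring at this place would shift the number beyond the scatter.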